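Compound 3 and a cytotoxicity limit

The source may report more compounds than this note shows. Statements on the series, on what has been measured and on what is new or still open speak of the compounds shown alone.

Compound 1 `CC(C)OC(=O)c1ccc(NCc2cncn2Cc2ccc(-c3ccccc3)cc2)cc1-c1ccccc1`: > 10000 nM
Compound 2 `Fc1ccc(Cn2cncc2CNc2ccc(-c3nc4ccccc4s3)c(-c3ccccc3)c2)c(F)c1`: > 1000 nM

Both entries come from a toxicity assay on NIH3T3 cells (Mus musculus) for cytotoxicity, read by resazurin assay; on this read-out higher numbers stand for an effect only at larger amounts of compound and lower numbers for an effect already at smaller amounts. In this assay compound 2 gives > 1000 nM, which is a limit and not a number. Compound 1 gives > 10000 nM, and this too is a limit. Neither compound therefore has an exact value, and the two cannot be placed in order.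

The next compound is compound 3 `CS(=O)(=O)c1ccc(Cn2cncc2CNc2ccc(-c3nc4ccccc4s3)c(-c3ccccc3)c2)cc1`. It differs from compound 2 in one place: 4-(methylsulfonyl)phenyl in place of 2,4-difluorophenyl on a saturated chain carbon bound to an aromatic nitrogen. Put in words, 4-(methylsulfonyl)phenyl stands in place of 2,4-difluorophenyl on a saturated chain carbon bound to an aromatic nitrogen, which also reads as 2,4-difluorobenzyl to 4-(methylsulfonyl)benzyl.

Going by the values given here, no measured pair of compounds shows what a change like this does, so any forecast is loose. The expectation rests on compound 2 with > 1000 nM, which points to an effect only at larger amounts. A small upward move is expected, and the estimated size is a step that the limit leaves unreadable from compound 2 to compound 3. In this assay only a limit may be reported again for compound 3. For compound 3 the estimated value is 3000 nM, with an expected range from 1000 nM to 12000 nM.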

Compound 3, half-maximal effective concentration: > 1000 nM
Compound 3 was reported as a limit; the forecaster's own chance of this, stated with the estimate: 80%; the middle value lies beyond the limit too.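

In this assay compound 3 gives > 1000 nM, which is a limit and not a number. Compound 2 is also known only as a limit, so the step between compound 2 and compound 3 cannot be read. The compounds shown leave open whether 4-(methylsulfonyl)phenyl in place of 2,4-difluorophenyl changes cytotoxicity at all.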